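Cytotoxicity of Thiazole Amides: From Bromophenyl to Trifluorophenyl

This account rests on a few compounds, and the source may have more. Where it says the series, first, only, none or still open, it means among the compounds named here.

The study followed a small set of compounds built on a shared core and tested each in an ADME assay on HepG2 2.2.15 cells (Homo sapiens) for cytotoxicity; on this read-out lower numbers stand for higher toxicity in this test and higher numbers for lower toxicity in this test. Compound 1 `COC(=O)CCCCNc1ncc(C(Oc2ccc3cc(Br)ccc3c2)c2ccc(Cl)cc2)s1` was recorded in this assay as "not toxic" (no number reported). Compound 2 `O=C(Nc1ncc(C(Oc2ccc3cc(Br)ccc3c2)c2ccc(Cl)cc2)s1)C1CCCO1` was likewise reported in this assay as "not toxic" (no number reported). Compound 3 `O=C(Nc1ncc(C(Oc2ccc3cc(Br)ccc3c2)c2ccc(Cl)cc2)s1)c1ccc(Br)cc1` gave in this assay a limit rather than a number, > 50000 nM. The only figure in the whole set is therefore (the limit of > 50000 nM in this assay, at which 1 of the 3 values shown sits), and the two other entries carry no number at all, so compound 3 stands at the low-toxicity end together with everything else shown.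

Compound 4 `O=C(Nc1ncc(C(Oc2ccc3cc(Br)ccc3c2)c2ccc(Cl)cc2)s1)c1cc(F)c(F)cc1F` has not yet been measured in this assay. It differs from compound 3 in a single place: 2,4,5-trifluorophenyl in place of 4-bromophenyl on a carbonyl carbon. Going by the values given here, no step between measured compounds is available for this core, so there is nothing to scale the change against. Given that every entry sits at the low-toxicity end, the step is expected to be a step that the limit leaves unreadable from compound 3 to compound 4, none beyond the usual scatter. Compound 4 is accordingly estimated at 60000 nM, within a range of 20000 nM to 200000 nM, and it is expected that this assay will most likely again report only a limit for it.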

Compound 4, half-maximal cytotoxic concentration: "not toxic" (no number reported)
For compound 4 the study gives words and no number, so the estimate cannot be set against anything.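

In this assay, going by these compounds alone, compound 4 was reported only in words and compound 3 carries only a limit, so no step from compound 3 to compound 4 can be read. The compounds shown leave open whether any of them, 4-bromophenyl or 2,4,5-trifluorophenyl alike, has a half-maximal cytotoxic concentration that can be stated as a number.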